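Swapping the side chain on a short-lived shared core

This account rests on a few compounds, and the source may have more. Where it says the series, first, only, none or still open, it means among the compounds named here.

Of the compounds shown here, two sharing one core have been measured so far. In an ADME assay on microsomes from liver (Homo sapiens) for metabolic stability, read by LC-MS, using NADPH, tested at 5 uM (on this read-out lower numbers stand for a shorter-lived compound and higher numbers for a longer-lived compound), compound 2 `NS(=O)(=O)c1cc(-c2nnc(CNS(=O)(=O)c3ccc(Cl)cc3)o2)c(Cl)cc1SCc1ccccc1` gives 0.197 h. Within the data shown here, its only neighbour, compound 1 `NS(=O)(=O)c1cc(-c2nnc(Cn3cc(-c4ccccc4)nn3)o2)c(Cl)cc1SCc1ccccc1`, gives 0.21 h in this assay, so the two numbers sit within the scatter of each other, and compound 2 stands beside rather than apart from compound 1. Compound 3 `NS(=O)(=O)c1cc(-c2nnc(/C=C/c3c(Cl)cccc3Cl)o2)c(Cl)cc1SCc1ccccc1` differs from compound 2 at one place: 2-(2,6-dichlorophenyl)ethenyl in place of (((4-chlorophenyl)sulfonyl)amino)methyl on an aromatic carbon. Among the measured compounds shown here, the one measured step that touches this spot is a 1.1-fold lower number from compound 1 to compound 2 (0.03 log units; within the scatter), where a different large group was exchanged on the same chain carbon and the number hardly moved. For the measured compounds named here, no measured step covers the group that enters here. Compound 3 is therefore expected to stay close to compound 2, with a 1.3-fold higher number from compound 2 to compound 3 (0.10 log units; within the scatter), and its estimated value is 0.25 h, in a range from 0.1 h to 0.7 h.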

Compound 3, half-life: 0.468 h
Beside the measured number, compound 3's estimate is 1.9-fold (0.27 log units) below it; low and high end bracket the measured number.
By their numbers in this assay, from the lowest: compounds 2 and 1 (each within the scatter of the next); then compound 3.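

Unlike the earlier exchange of one large group for another, this change at the aromatic carbon of the five-membered ring moves the number in this assay: a 2.4-fold higher number from compound 2 to compound 3 (0.38 log units; beyond the scatter), and a 2.2-fold higher number from compound 1 to compound 3 (0.35 log units; beyond the scatter). Both steps are modest but beyond the scatter, so the half-life at this position does depend on the group attached, although the two chains joined through a saturated carbon gave much the same number. Nothing available explains why the 2-(2,6-dichlorophenyl)ethenyl group gives the longer half-life.

The compounds shown cannot separate the part played by the ethenyl link from that of the two chlorines on the phenyl ring. An unsubstituted phenyl on the same ethenyl link, or a saturated two-carbon chain carrying the 2,6-dichlorophenyl ring, would pull those two apart.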